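Hydroxy in Place of Carboxy: Still Well Tolerated?

This account rests on a few compounds, and the source may have more. Where it says the series, first, only, none or still open, it means among the compounds named here.

In an ADME assay on L929 cells (Mus musculus) for cytotoxicity, read by resazurin assay, with a stated time of 48 h (a higher number here means that more compound is tolerated, a lower number that less compound is tolerated), compound 1 `O=c1c2cc([N+](=O)[O-])ccc2n(CCCBr)n1Cc1ccccc1` gives 25200 nM. Compound 2 `N#CCn1c2ccc([N+](=O)[O-])cc2c(=O)n1Cc1ccccc1` reads > 256000 nM, which is a limit of the assay. From the compounds shown here alone, compound 3 `O=C(O)CCCn1c2ccc([N+](=O)[O-])cc2c(=O)n1Cc1ccccc1` reads > 256000 nM, which is also a limit, so its true position is unknown. Compound 4 `O=c1c2cc([N+](=O)[O-])ccc2n(CCCO)n1Cc1ccccc1` carries hydroxy in place of carboxy on a saturated chain carbon, three bonds along the chain from an aromatic nitrogen. Like compound 2 and compound 3, it has no bromo. Removing bromo gave an at least 10-fold higher number from compound 1 to compound 3 (1.00 log units; beyond the scatter) and, with a different replacement, an at least 10-fold higher number from compound 1 to compound 2 (1.00 log units; beyond the scatter). These steps suggest that compound 4 should stay near the limit in this assay, with no large drop expected. The estimated step is an at least 1.1-fold lower number from compound 3 to compound 4 (0.06 log units; that floor lies within the scatter). For compound 4, the expected value is 220000 nM, within an estimated range from 80000 nM to 450000 nM.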

Compound 4, concentration lethal to 50% of the cells: > 256000 nM
Compound 4 was reported as a limit; the forecaster's own chance of this, stated with the estimate: 55%; middle value at least 1.1-fold (0.06 log units) away from the limit.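

In this assay compound 4 gives > 256000 nM as a limit of the assay. Hydroxy in place of bromo on this chain carbon gives an at least 10-fold higher number from compound 1 to compound 4 (1.00 log units; beyond the scatter) and so makes compound 4 the third compound without bromo to reach that limit. The steps from compound 2 and from compound 3 to compound 4 cannot be read, and the order among these compounds stays unknown: the limit of > 256000 nM in this assay, at which 3 of the 4 values shown sit.

From the compounds shown here alone, whether hydroxy differs from carboxy or cyano at all stays open. Going by these compounds, it is also open whether an amine at this place, or a longer chain ending in hydroxy, would stay as well tolerated.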